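Compound 2 gains an amino(ethylsulfanyl)methyl group

The source may hold more compounds than are shown below. What is called first, only, known or untested is meant among the compounds shown, and "the series" means these compounds.

Of the compounds shown here, three sharing one core have been tested in an ADME assay (Homo sapiens) for cytotoxicity; a higher number here means that more compound is tolerated, a lower number that less compound is tolerated. Compound 1 `Nc1nn2c(O)cc(-c3ccc(F)cc3)nc2c1[N+](=O)[O-]` gives > 100 ug/mL, which is a limit of the assay and not a number. Compound 2 `NNCc1cc(O)n2nc(N)c([N+](=O)[O-])c2n1` gives 42.6 ug/mL and compound 3 `COc1ccc(NNCc2cc(O)n3nc(N)c([N+](=O)[O-])c3n2)cc1` gives 66.3 ug/mL, two values within the usual scatter of each other. Among the compounds with values here, compound 2 therefore stands level with compound 3, the only other compound with a true number.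

The next compound, compound 4 `CCSC(N)NCc1cc(O)n2nc(N)c([N+](=O)[O-])c2n1`, differs from compound 2 in one place: amino(ethylsulfanyl)methyl in place of amino on an amine nitrogen. Amino(ethylsulfanyl)methyl stands in place of amino on an amine nitrogen.

Within the data shown here, two measured steps bear on this change. The closer one is a 1.6-fold higher number from compound 2 to compound 3 (0.19 log units; within the scatter), where 4-methoxyphenyl replaces hydrogen, also on an amine nitrogen. The other, an at least 2.3-fold lower number from compound 1 to compound 2 (0.37 log units; beyond the scatter), goes beyond the scatter, but it replaces 4-fluorophenyl with (aminoamino)methyl on an aromatic carbon, so it says less about this change. Going by compound 3 at 66.3 ug/mL, the single comparable case, only a small shift is expected.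

The expected result is a 1.2-fold higher number from compound 2 to compound 4 (0.09 log units; within the scatter), which would be no step beyond the scatter. For compound 4 the estimated value is 52 ug/mL, with an expected range from 25 ug/mL to 100 ug/mL.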

Compound 4, half-maximal cytotoxic concentration: > 50 ug/mL
Compound 4 ended at the assay's limit; the forecaster's own chance of this, stated with the estimate: 15%; the middle value lies beyond the limit too.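

In this assay compound 4 gives > 50 ug/mL, which is a limit of the assay and not a number. Placing amino(ethylsulfanyl)methyl in place of amino on this amine nitrogen gives an at least 1.1-fold higher number from compound 2 to compound 4 (0.06 log units; that floor lies within the scatter), so five heavy atoms can stand where one stood with no drop beyond the scatter. Until now, the only change shown on an amine nitrogen was the ring-bearing 4-methoxyphenyl group, at a 1.6-fold higher number from compound 2 to compound 3 (0.19 log units; within the scatter), and a group with no ring that carries a sulfur atom now shows no drop beyond the scatter either.

The true size of the step to compound 4 stays open, and the step from compound 1 to compound 4 cannot be read, because the reading for compound 4 stops at a limit: the limit of > 50 ug/mL in this assay, at which 1 of the 4 values shown sits. The compounds shown also leave open how a carboxylic acid or a longer plain carbon chain would fare on this same amine nitrogen.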